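A few compounds are considered here, and "the series" means these few. Any claim that something is new, unique, unknown or untested is made for them only; others in the source may bear on it.

Compound 1 `NC1=NC2(CCOCC2)N(OCCCOc2ccccc2Cl)C(N)=N1` and compound 2 `NC1=NC2(CCOCC2)N(OCCCOc2ccccc2Br)C(N)=N1` share one core and differ only in the halogen on the phenoxy ring. In a functional assay on HCT-116 cells (Homo sapiens) for antiproliferative activity, read by MTT assay, with a stated time of 72 h (a lower number here means a stronger inhibitor, a higher number a weaker inhibitor), compound 1 gives 70 nM, and compound 2 gives 30 nM. The change chloro in place of bromo on an aromatic carbon thus produced a 2.3-fold higher number from compound 2 to compound 1 (0.37 log units; beyond the scatter). Compound 3 `NC1=NC2(CCSCC2)N(OCCCOc2ccccc2Br)C(N)=N1` carries the bromo group on a different core; the difference between the two cores is not broken down here. In this assay compound 3 gives 1 nM, the lowest of the three numbers. Compound 4 `NC1=NC2(CCSCC2)N(OCCCOc2ccccc2Cl)C(N)=N1` has the same change, (chloro in place of bromo on an aromatic carbon), made on the core of compound 3. Because a 2.3-fold higher number from compound 2 to compound 1 (0.37 log units; beyond the scatter) was modest, a step of similar size is expected for compound 4, namely a 2.5-fold higher number from compound 3 to compound 4 (0.40 log units; beyond the scatter). The value expected for compound 4 in this assay is 2.5 nM, within a range from 1 nM to 7 nM.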

Compound 4, half-maximal inhibitory concentration: 1 nM
The estimate for compound 4 lay 2.5-fold (0.40 log units) above the measured number; measured number inside the range.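

In this assay, chloro in place of bromo on an aromatic carbon gave no change at the digits printed from compound 3 to compound 4 (within the scatter). Set beside the earlier step, the change carries over from one core to the other without a difference that can be told apart: the same change on two cores in this assay, a 2.3-fold higher number (0.37 log units; beyond the scatter) from compound 2 to compound 1 and no change at the digits printed (within the scatter) from compound 3 to compound 4, 2.3-fold (0.37 log units) apart, within the scatter of two such steps. Going by these compounds alone, this shows only that the two steps agree within the scatter on these two cores; two pairs do not make a rule for the series, and they do not show why the numbers fall as they do.

The compounds shown leave open how fluoro, methoxy or trifluoromethyl would compare with these two halogens on either core. They also leave open what a longer chain would do.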